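The source may report more compounds than this note shows. Statements on the series, on what has been measured and on what is new or still open speak of the compounds shown alone.

Compound 1 `CCO/C(O)=C1\C(COCCn2nncc2C(N)=O)=NC(C)=C(C(=O)OC)C1c1cccc(Cl)c1Cl`: in a functional assay (aorta) with Rattus norvegicus as the target (on this read-out higher numbers stand for weaker inhibition and lower numbers for stronger inhibition), compound 1 gives 15.9 nM.
Compound 2 `CCO/C(O)=C1\C(COCCN2CC(=O)N=C2N)=NC(C)=C(C(=O)OC)C1c1ccccc1Cl`: in this assay compound 2 gives 20 nM.

Only these two compounds have been measured so far, and their two numbers lie within the usual scatter of repeated measurements of each other. Compound 2 therefore cannot be told apart from compound 1 on these data; the two values simply sit close together, and neither can be called the more or less active of the pair.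

Compound 3 `CCO/C(O)=C1\C(COCCn2cc(N)nc2O)=NC(C)=C(C(=O)OC)C1c1ccccc1Cl` has not yet been measured. It keeps every atom of compound 2 and changes only how a group of them is joined together: a group of 7 heavy atoms (3 carbon, 3 nitrogen, 1 oxygen; one five-membered aromatic ring with 2 hetero atoms) in place of a group of 7 heavy atoms (3 carbon, 3 nitrogen, 1 oxygen; one five-membered non-aromatic ring with 2 hetero atoms), on a saturated chain carbon, two bonds along the chain from an oxygen on a saturated carbon. The rest of the shared core, including the ester and the chlorinated phenyl ring, is untouched.

Within the data shown here, no measured pair in this set shows a change of this kind, so there is no step to lean on. Since the atoms stay the same and only their arrangement within one small ring changes, the expectation is that compound 3 stays close to compound 2, with a step of no change at the digits printed from compound 2 to compound 3 (within the scatter) that is not expected to go beyond the scatter in either direction. Compound 3 is expected to give about 20 nM in this assay, with a range from 8 nM to 50 nM.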

Compound 3, half-maximal inhibitory concentration: 31.6 nM
Compound 3: middle estimate off by 1.6-fold (0.20 log units), on the low side, and the stated range covers the measured number.
By their numbers in this assay, from the lowest: compounds 1, 2 and 3 (each within the scatter of the next).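

In this assay, putting the 4-amino-2-hydroxy-1H-imidazol-1-yl group in place of the non-aromatic five-membered ring gives a 1.6-fold higher number from compound 2 to compound 3 (0.20 log units; within the scatter). Among these compounds, this is the first pair in the set that differs in one place, and it shows that on a saturated chain carbon, two bonds along the chain from an oxygen on a saturated carbon, the same atoms can be joined as either an aromatic or a non-aromatic ring with no difference that can be told from the scatter. No separate measurement is available that would explain this result.

A single pair cannot show how far this position accepts groups of other kinds, such as a simple amine, a carboxylic acid or a longer chain ending in an amide. It also leaves open whether the same exchange of rings would give a similar step with the phenyl ring carrying a second chlorine, as it does in compound 1.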